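This account rests on a few compounds, and the source may have more. Where it says the series, first, only, none or still open, it means among the compounds named here.

Of the compounds shown here, three that share one core have been measured in a functional assay on cells for agonist activity at Free fatty acid receptor 1 (Homo sapiens), read by FLIPR and calcium flux, with a stated time of 60 min; on this read-out lower numbers stand for smaller maximal responses and higher numbers for larger maximal responses. Compound 1 `COc1ccc(C)c(N2CCC(COc3cccc(C(CC(=O)O)C4CC4)c3)CC2)c1` gives 113%, compound 2 `COc1ccc(C(C)C)c(N2CCC(COc3cccc(C(CC(=O)O)C4CC4)c3)CC2)c1` gives 117%, and compound 3 `COc1ccc(CCC(C)(C)O)c(N2CCC(COc3cccc(C(CC(=O)O)C4CC4)c3)CC2)c1` gives 109%. Compound 3 shows the lowest of the three numbers, yet the step of a number 4 percentage points lower from compound 1 to compound 3 (within the scatter) and the step of a number 8 percentage points lower from compound 2 to compound 3 (within the scatter) both stay within the scatter, so the three cannot be told apart. Compound 4 `COc1ccc(C(=O)N(C)CC(C)(C)C)c(N2CCC(COc3cccc(C(CC(=O)O)C4CC4)c3)CC2)c1` differs from compound 3 at the same aromatic carbon: methyl(neopentyl)carbamoyl in place of 3-hydroxy-3-methylbutyl on an aromatic carbon. The two steps that changed this position, a number 4 percentage points higher from compound 1 to compound 2 (within the scatter) and a number 8 percentage points lower from compound 2 to compound 3 (within the scatter), stayed within the scatter, so no step beyond the scatter is expected in this assay for compound 4, whose value is estimated at 110% (range 95% to 125%), a shift of a number 1 percentage points higher from compound 3 to compound 4 (within the scatter).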

Compound 4, largest response reached (Emax), in percent of the reference or control that the assay uses: 107%
Beside the measured number, compound 4's estimate is 3 percentage points above it, within the range that was stated.
By their numbers in this assay, from the lowest: compounds 4, 3, 1 and 2 (each within the scatter of the next).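

Methyl(neopentyl)carbamoyl is the largest group shown at this aromatic carbon, with 9 heavy atoms, and it has 0 hydrogen-bond donors where 3-hydroxy-3-methylbutyl has 1, yet this assay gives a number 2 percentage points lower from compound 3 to compound 4 (within the scatter), a number 10 percentage points lower from compound 2 to compound 4 (within the scatter) and a number 6 percentage points lower from compound 1 to compound 4 (within the scatter). Across these four compounds, then, neither that larger group nor the loss of the hydrogen-bond donor separates the maximal responses. No supporting measurement is available to explain this result. Going by these compounds, whether an aminomethyl group or a nitrile at this aromatic carbon would move the response beyond the scatter stays open.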